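This account rests on a few compounds, and the source may have more. Where it says the series, first, only, none or still open, it means among the compounds named here.

Compound 1 `O=C1COc2ccc(-c3cccc(NS(=O)(=O)c4ccc(F)cc4)c3)cc2N1C1CC1` was tested in a functional assay on HeLa cells (Homo sapiens) for antiproliferative activity, read by MTT assay, with a stated time of 72 h (a higher number here means a weaker inhibitor, a lower number a stronger inhibitor), where it gives only a limit of > 40000 nM, not a number. Compound 2 `COc1cccc(N2C(=O)COc3ccc(-c4ccc(O)cc4)cc32)c1` likewise returns only a limit in this assay, namely > 40000 nM. Both values therefore rest at the same edge of what the measurement reports, as shown by the limit of > 40000 nM in this assay, at which 2 of the 2 values shown sit, and no step between them can be sized or given a direction. Compound 3 `Cc1ccc(N2C(=O)COc3ccc(-c4cccc(NS(=O)(=O)c5ccc(F)cc5)c4)cc32)cc1` has not yet been measured in this assay. It differs from compound 1 in one place: 4-methylphenyl in place of cyclopropyl on an amide-type nitrogen in a ring. Among the measured compounds shown here, with both measured compounds at the limit, there is no step from which to set a direction, so the estimated change from this swap is expected to be none beyond the scatter, a number no higher from compound 1 to compound 3 (the limit leaves the size open). For compound 3 the expected value is 40000 nM, with a range from 12000 nM to 120000 nM, and a limit rather than a number remains the likelier outcome.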

Compound 3, half-maximal inhibitory concentration: > 40000 nM
Compound 3 gave a limit, no number (the forecaster's own chance of this, stated with the estimate: 70%); the middle value lies on the limit itself.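

No step from compound 1 to compound 3 can be read, because both compounds give a limit rather than a number: the limit of > 40000 nM in this assay, at which 3 of the 3 values shown sit.

The compounds shown leave open how 4-methylphenyl and cyclopropyl compare in this assay, and which change to the shared core, if any, would give a number there.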